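Trifluoromethyl in place of methoxy: expectation for compound 4

A few compounds are considered here, and "the series" means these few. Any claim that something is new, unique, unknown or untested is made for them only; others in the source may bear on it.

Three members of the series have numbers in a functional assay on HeLa cells (Homo sapiens) for cytotoxicity, read by MTT assay, with a stated time of 72 h; a lower number here means a stronger inhibitor, a higher number a weaker inhibitor. Compound 1 `COc1ccc(/C=C/C(=O)Nc2cc(C(=O)c3cc(OC)c(OC)c(OC)c3)ccc2OC)cc1` gives 10700 nM. Compound 2 `COc1ccc(C(=O)c2cc(OC)c(OC)c(OC)c2)cc1NC(=O)/C=C/c1ccc([N+](=O)[O-])cc1` gives 8500 nM; the step of a 1.3-fold lower number from compound 1 to compound 2 (0.10 log units; within the scatter) puts nitro in place of methoxy on an aromatic carbon. Compound 3 `COc1ccc(/C=C/C(=O)Nc2cc(C(=O)c3cc(OC)c(OC)c(OC)c3)cc(OC)c2OC)cc1` gives 11200 nM; the step of a 1.0-fold higher number from compound 1 to compound 3 (0.02 log units; within the scatter) puts methoxy in place of hydrogen on an aromatic carbon. Compound 3 thus holds the highest of the three numbers, but its gaps to compound 1 and to compound 2 are both within the scatter, so no order among the three can be read from these values.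

Compound 4 `COc1cc(C(=O)c2cc(OC)c(OC)c(OC)c2)cc(NC(=O)/C=C/c2ccc(C(F)(F)F)cc2)c1OC` is not yet measured. It differs from compound 3 by trifluoromethyl in place of methoxy on an aromatic carbon. Among the measured compounds shown here, the only measured step that also replaces a methoxy on an aromatic carbon, a 1.3-fold lower number from compound 1 to compound 2 (0.10 log units; within the scatter), stayed within the scatter; no measured step involves trifluoromethyl. The step of a 1.1-fold lower number from compound 3 to compound 4 (0.05 log units; within the scatter) is therefore expected to stay within the scatter, with no direction favoured. Compound 4 is estimated at 10000 nM, with a range from 4000 nM to 25000 nM.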

Compound 4, half-maximal inhibitory concentration: 3000 nM
Compound 4: the middle estimate sits 3.3-fold (0.52 log units) above what was measured; the whole stated range lies above it.
By their numbers in this assay, from the lowest: compound 4; then compounds 2, 1 and 3 (each within the scatter of the next).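

In this assay, among the compounds shown here, replacing the methoxy of the 4-methoxyphenyl group with trifluoromethyl gives a 3.7-fold lower number from compound 3 to compound 4 (0.57 log units; beyond the scatter) and is the only step that lies beyond the scatter. This shows that the number can respond to a change at this aromatic carbon, which a 1.3-fold lower number from compound 1 to compound 2 (0.10 log units; within the scatter) did not show when nitro replaced the same methoxy on the core of compound 1. Nothing available explains the step with trifluoromethyl.

From the compounds shown here alone, the two replacements were read on different cores, so it remains open whether trifluoromethyl would give a similar step on the core of compound 1 and how nitro would behave on the core of compound 3. Going by these compounds, how a chlorine atom, a nitrile or an amine at this place would compare also remains open.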